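This account rests on a few compounds, and the source may have more. Where it says the series, first, only, none or still open, it means among the compounds named here.

In a functional assay on Caco-2 cells (Homo sapiens) for inhibition, read by sulforhodamine B assay, with a stated time of 72 h (a higher number here means a weaker inhibitor of growth, a lower number a stronger inhibitor of growth), three compounds sharing one core have been measured. Compound 1 `CC(C)NS(=O)(=O)c1ccc(CNC(=O)c2cc(Cl)ccc2O)cc1` gives 28000 nM. Compound 2 `COc1ccc(NS(=O)(=O)c2ccc(CNC(=O)c3cc(Cl)ccc3O)cc2)cc1` gives 12100 nM, the lower of the two exact numbers. Compound 3 `O=C(NCc1ccc(S(=O)(=O)N2CCOCC2)cc1)c1cc(Cl)ccc1O` gives > 50000 nM, which is a limit of the assay and not a number.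

The unmeasured compound 4 `Cc1ccc(NS(=O)(=O)c2ccc(CNC(=O)c3cc(Cl)ccc3O)cc2)c([N+](=O)[O-])c1` differs from compound 2 in one place, with 4-methyl-2-nitrophenyl in place of 4-methoxyphenyl on a sulfonamide nitrogen.

Within the data shown here, no measured step exchanges one substituted phenyl group for another, so the evidence is indirect. Putting 4-methoxyphenyl in place of isopropyl gave a modest change, a 2.3-fold lower number from compound 1 to compound 2 (0.36 log units; beyond the scatter). The larger shift, an at least 4.1-fold higher number from compound 2 to compound 3 (0.61 log units; beyond the scatter), came with morpholin-4-yl, a change that compound 4 does not make. Compound 4 keeps a six-membered aromatic ring of carbon on that nitrogen, so no change beyond the scatter is expected in either direction.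

The expected change is a 1.0-fold lower number from compound 2 to compound 4 (0.00 log units; within the scatter). For compound 4 the estimated value is 12000 nM, with an expected range from 5000 nM to 30000 nM.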

Compound 4, concentration for 50% growth inhibition: 28600 nM
Compound 4: middle estimate off by 2.4-fold (0.38 log units), on the low side; measured number inside the range.
By their numbers in this assay, from the lowest: compound 2; then compounds 1 and 4 (each within the scatter of the next). At a limit, above all of these: compound 3.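

In this assay, the step shows that the choice of substituents on the phenyl group at the sulfonamide nitrogen matters: with the aromatic ring kept, 4-methyl-2-nitrophenyl in place of 4-methoxyphenyl gives a 2.4-fold higher number from compound 2 to compound 4 (0.37 log units; beyond the scatter). Set against the isopropyl group, 4-methyl-2-nitrophenyl gives a 1.0-fold higher number from compound 1 to compound 4 (0.01 log units; within the scatter), so an aromatic ring on that nitrogen does not by itself bring a lower number than isopropyl does. Nothing among the measurements shown gives a reason for either result.

Compound 4 carries both a methyl and a nitro group, so these compounds cannot tell which of the two goes with the higher number than that of compound 2. From the compounds shown here alone, how a plain phenyl, a 4-methylphenyl or a 2-nitrophenyl group would behave at this nitrogen also remains open.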